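The source may report more compounds than this note shows. Statements on the series, on what has been measured and on what is new or still open speak of the compounds shown alone.

Measured so far:
- compound 1 `CC(C)[C@H](C(=O)NC1=NC(=O)CS1)c1ccc(Cl)cc1`: 20000 nM
- compound 2 `CC(C)[C@H](C(=O)Nc1nc(C(C)(C)C)cs1)c1ccc(Cl)cc1`: 7900 nM
- compound 3 `C[C@H](C(=O)Nc1nccs1)c1ccc(Cl)cc1`: 46000 nM

In a functional assay on CHO cells for agonist activity at Free fatty acid receptor 2 (Homo sapiens), read by cAMP accumulation (on this read-out lower numbers stand for stronger inhibition and higher numbers for weaker inhibition), compound 3 gives 46000 nM, the highest of the three numbers; compound 1 and compound 2 both sit beyond the scatter below it. Compound 4 `CCC[C@H](C(=O)Nc1nccs1)c1ccc(Cl)cc1` is not yet measured. It differs from compound 3 in one place: ethyl in place of hydrogen on a saturated chain carbon, two bonds along the chain from an aromatic carbon and a carbonyl carbon. Among the compounds with values here, no step between measured compounds isolates this change, so the expectation rests on the fact that the two other compounds, which carry more on that chain carbon, give lower numbers than compound 3. A moderate step downward, beyond the scatter, is expected from compound 3 to compound 4, a 3.1-fold lower number from compound 3 to compound 4 (0.49 log units; beyond the scatter). Compound 4 is therefore estimated at 15000 nM, within a range from 5000 nM to 50000 nM.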

Compound 4, half-maximal inhibitory concentration: 5500 nM
For compound 4 the middle estimate is 2.7-fold (0.44 log units) above the measured one, within the range that was stated.
By their numbers in this assay, from the lowest: compounds 4 and 2 (each within the scatter of the next); then compound 1; then compound 3.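

In this assay, within the data shown here, ethyl in place of hydrogen on this saturated chain carbon brings an 8.4-fold lower number from compound 3 to compound 4 (0.92 log units; beyond the scatter) and so gives the first single-place reading at this position. The earlier compounds shown here differed from one another in more than one place, so they could not show that this change alone moves the number beyond the scatter. Nothing at hand explains the size of this step.

As far as these compounds go, whether a longer chain such as pentyl would lower the number further remains open. So does the effect of an amine or a carboxylic acid at the end of the chain.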